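Acetoxy in place of hydrogen on a saturated ring carbon

The compounds below may be only part of what the source reports. "The series", "measured", "known", "first", "only" and "open" are said of these compounds alone.

Measured compounds:
compound 1 `C=C1C(=O)O[C@@H]2[C@@H]1C[C@H](OC(C)=O)[C@](C)(O)CC/C=C(\C)CC/C=C(\C)[C@@H]2OC(C)=O` gives 10.3 ug/mL
compound 2 `C=C1C(=O)O[C@H]2C/C(C)=C/CC/C(C)=C/CC[C@@](C)(O)[C@@H](O)C[C@H]12` gives 15.3 ug/mL

In a functional assay on MCF7 cells (Homo sapiens) for cytotoxicity, read by colorimetric assay and MTT assay (on this read-out lower numbers stand for stronger inhibition and higher numbers for weaker inhibition), compound 2 has the highest of the two numbers, yet its nearest neighbour, compound 1, lies within the usual scatter of it, so the two values show no real difference. Compound 3 `C=C1C(=O)O[C@@H]2[C@@H]1C[C@H](O)[C@](C)(O)CC/C=C(\C)CC/C=C(\C)[C@@H]2OC(C)=O` has not yet been measured. Compared with compound 2 it carries acetoxy in place of hydrogen on a saturated ring carbon. Among the compounds with values here, no step between measured compounds separates the effect of this change on its own. Because compound 1 gives 10.3 ug/mL while carrying an acetoxy group on a ring carbon, and because compound 2 gives 15.3 ug/mL, no step beyond the scatter is expected here. The step of a 1.3-fold lower number from compound 2 to compound 3 (0.11 log units; within the scatter) is therefore estimated to be small, in no definite direction. Compound 3 is expected to give about 12 ug/mL in this assay, with a range from 5 ug/mL to 30 ug/mL.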

Compound 3, half-maximal inhibitory concentration: 8.9 ug/mL
Compound 3: middle estimate off by 1.3-fold (0.13 log units), on the high side, and the stated range covers the measured number.
By their numbers in this assay, from the lowest: compounds 3, 1 and 2 (each within the scatter of the next).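

With acetoxy in place of hydrogen on this saturated ring carbon, this assay shows a 1.7-fold lower number from compound 2 to compound 3 (0.24 log units; within the scatter), so the group is tolerated here without a change beyond the scatter. The second step, hydrogen in place of acetyl on an oxygen on a saturated carbon, gives a 1.2-fold lower number from compound 1 to compound 3 (0.06 log units; within the scatter), so this site also shows no real difference, and compound 1, compound 2 and compound 3 cannot be ranked. Nothing available explains why either change leaves the read-out within the scatter.

The compounds shown leave open whether a larger ester such as benzoyloxy, or an amine, on the same ring carbon would move the number beyond the scatter. They also leave open whether a group other than hydrogen or acetyl on the second oxygen would do so.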